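The compounds below may be only part of what the source reports. "The series", "measured", "known", "first", "only" and "open" are said of these compounds alone.

Compounds measured in a functional assay on HeLa cells (Homo sapiens) for cytotoxicity, read by MTT assay, with a stated time of 72 h; a lower number here means a stronger inhibitor, a higher number a weaker inhibitor:

Compound 2, `NS(=O)(=O)c1cc(-c2nnc(Cn3cc(-c4ccccc4)nn3)o2)c(Cl)cc1SCc1ccccc1` — 7000 nM
Compound 1, `Cc1ccc(C)c(N2CCN(Cc3nnc(-c4cc(S(N)(=O)=O)c(SCc5ccccc5)cc4Cl)o3)CC2)c1` — 16000 nM
Compound 3, `COc1ccc(-c2cn(Cc3nnc(-c4cc(S(N)(=O)=O)c(SCc5ccccc5)cc4Cl)o3)nn2)cc1` — 68000 nM

Compound 2 gives the lowest number of the three in this assay. Compound 1 gives a higher number, a gap beyond the scatter, and compound 3 gives the highest number of the set. Among the measured compounds shown here, the one step measured in a single place, a 9.7-fold higher number from compound 2 to compound 3 (0.99 log units; beyond the scatter), shows that a small addition on the phenyl ring of compound 2 already raises the number well beyond the scatter.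

Compound 4, `NS(=O)(=O)c1cc(-c2nnc(/C=C/c3cccc(Cl)c3)o2)c(Cl)cc1SCc1ccccc1`, differs from compound 2 by 2-(3-chlorophenyl)ethenyl in place of (4-phenyl-1H-1,2,3-triazol-1-yl)methyl on an aromatic carbon. For the measured compounds named here, no measured step covers this exchange: the triazole and its phenyl both leave, and an open-chain double bond carrying a chlorinated phenyl enters in their place. Going by the values given here, the one measured step, a 9.7-fold higher number from compound 2 to compound 3 (0.99 log units; beyond the scatter), raises the number. Compound 1 also gives a higher number than compound 2. So on these data a modest rise is the more likely expectation for compound 4, though the direction is uncertain. The estimate for compound 4 in this assay is 12000 nM, in the range 3500 nM to 40000 nM, a step of a 1.7-fold higher number from compound 2 to compound 4 (0.23 log units; within the scatter) from compound 2, expected to fall within or just beyond the scatter.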

Compound 4, half-maximal inhibitory concentration: 16000 nM
Estimate against measurement, compound 4: 1.3-fold (0.12 log units) below; the range from low to high includes it.
By their numbers in this assay, from the lowest: compound 2; then compounds 1 and 4 (each within the scatter of the next); then compound 3.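

In this assay, 2-(3-chlorophenyl)ethenyl in place of (4-phenyl-1H-1,2,3-triazol-1-yl)methyl gives a 2.3-fold higher number from compound 2 to compound 4 (0.36 log units; beyond the scatter), so a group without a triazole can stand at this position on the five-membered aromatic ring and the number stays in the same general range. This whole exchange of group moves the number less than the single methoxy of the earlier step, a 9.7-fold higher number from compound 2 to compound 3 (0.99 log units; beyond the scatter). Nothing measured here accounts for the rise seen with this exchange.

The compounds shown leave open how much of the value of compound 4 belongs to the chlorine and how much to the double bond outside the aromatic rings. They also leave open what an amine or a carboxylic acid in place of that chlorine would do to the number.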